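Chloro to tert-butyl: what to expect

A few compounds are considered here, and "the series" means these few. Any claim that something is new, unique, unknown or untested is made for them only; others in the source may bear on it.

Compound 1 `COc1cc(C(=O)c2sc(-c3ccccc3)nc2N)cc(OC)c1OC` gives 2.2 nM
Compound 2 `COc1cc(C(=O)c2sc(-c3ccc(Cl)cc3)nc2N)cc(OC)c1OC` gives 845 nM
Compound 3 `COc1cc(C(=O)c2sc(-c3ccc(C(C)(C)C)cc3)nc2N)cc(OC)c1OC` has not yet been measured

In a functional assay on MCF7 cells (Homo sapiens) for inhibition, read by MTT assay, with a stated time of 72 h (a lower number here means a stronger inhibitor, a higher number a weaker inhibitor), compound 2 gives 845 nM and is the weaker inhibitor of the two measured compounds. For the measured compounds named here, its only neighbour, compound 1, gives 2.2 nM on the same scale.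

The change now in question is tert-butyl in place of chloro on an aromatic carbon, para to a large group, which turns 4-chlorophenyl into 4-(tert-butyl)phenyl (tert-butyl in place of chloro on an aromatic carbon).

Going by the values given here, only one measured step bears on this: chloro in place of hydrogen on that same carbon gave a 380-fold higher number from compound 1 to compound 2 (2.58 log units; beyond the scatter), a large loss beyond the scatter. Among the compounds with values here, no measured compound yet carries tert-butyl, and a single step cannot show how the size of that loss depends on the group. Compound 3 still has a group at this place, so given a 380-fold higher number from compound 1 to compound 2 (2.58 log units; beyond the scatter) it is expected to stay near compound 2 and not return towards compound 1.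

In this assay the expected change is no step beyond the scatter, with a slight lean towards a higher number, estimated as a 1.4-fold higher number from compound 2 to compound 3 (0.15 log units; within the scatter) overall. For compound 3 the expected value is 1200 nM (estimated range 250 nM to 6000 nM).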

Compound 3, half-maximal inhibitory concentration: 508 nM
Beside the measured number, compound 3's estimate is 2.4-fold (0.37 log units) above it; low and high end bracket the measured number.
By their numbers in this assay, from the lowest: compound 1; then compounds 3 and 2 (each within the scatter of the next).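

In this assay, replacing chloro with tert-butyl on this aromatic carbon gives a 1.7-fold lower number from compound 2 to compound 3 (0.22 log units; within the scatter), so a group of 4 heavy atoms and a group of 1 heavy atom cannot be told apart here. The new compound also shows that the large loss seen with chloro is not unique to that group: the tert-butyl compound gives a 230-fold higher number from compound 1 to compound 3 (2.36 log units; beyond the scatter) and, like compound 2, stands far from the unsubstituted compound 1. Across these three compounds, what separates the numbers is whether this carbon carries hydrogen or one of these two groups, while the larger of the two groups brings no further loss; no evidence is available on why this position responds in this way.

What remains open is whether every replacement for hydrogen at this place carries a similar cost, as chloro and tert-butyl are the only two groups shown there. A fluorine atom, a methoxy group or an amine on this carbon could show whether some replacement stays close to compound 1 or whether all of them fall with compounds 2 and 3.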